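A few compounds are considered here, and "the series" means these few. Any claim that something is new, unique, unknown or untested is made for them only; others in the source may bear on it.

The three measured compounds share one core and differ only in the aromatic group on a saturated chain carbon bound to an amine nitrogen in a ring and an aromatic carbon. In a functional assay on cells (Rhabdomyosarcoma cell, Homo sapiens) for cytotoxicity (a lower number here means a stronger inhibitor, a higher number a weaker inhibitor), compound 1 `Cc1ccccc1C(c1ccccc1)N1CCN(c2ncnc3c2cnn3-c2ccccc2)CC1` gives a reading that is a limit of the assay, > 25000 nM. Compound 2 `c1ccc(C(c2cccnc2)N2CCN(c3ncnc4c3cnn4-c3ccccc3)CC2)cc1` likewise returns only a limit in this assay, > 25000 nM. Compound 3 `Cc1ccsc1C(c1ccccc1)N1CCN(c2ncnc3c2cnn3-c2ccccc2)CC1` also stops at a limit in this assay, > 25000 nM. Compound 3 thus stands with the other two at the edge of what the assay reports, not at a number; all three sit at the limit of > 25000 nM in this assay, at which 3 of the 3 values shown sit. The steps between them, a step that the two limits leave unreadable from compound 1 to compound 2, a step that the two limits leave unreadable from compound 1 to compound 3 and a step that the two limits leave unreadable from compound 2 to compound 3, have no readable size. Compound 4 `c1ccc(C(c2nccs2)N2CCN(c3ncnc4c3cnn4-c3ccccc3)CC2)cc1` is the next member: 1,3-thiazol-2-yl in place of 3-methylthiophen-2-yl on a saturated chain carbon bound to an amine nitrogen in a ring and an aromatic carbon. Among the measured compounds shown here, none of the measured steps gives a readable size for exchanging one aromatic group for another at this position, so no direction can be drawn from them, and the expectation rests on (the limit of > 25000 nM in this assay, at which 3 of the 3 values shown sit). Compound 4 is accordingly expected to give 30000 nM, with a range from 25000 nM to 100000 nM, most likely again as a limit rather than a number. The estimated step is a step that the limit leaves unreadable from compound 3 to compound 4, meaning that no change beyond the scatter is expected.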

Compound 4, half-maximal inhibitory concentration: > 25000 nM
Compound 4: only a limit was reported (the forecaster's own chance of this, stated with the estimate: 85%); the middle value is on the limit's open side.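

Compound 4 also returns only a limit in this assay, > 25000 nM, so none of its steps from compound 1, compound 2 or compound 3 can be read. The compounds shown leave open whether any aromatic group at this place gives a measurable value in this assay, as all of them rest at one edge: the limit of > 25000 nM in this assay, at which 4 of the 4 values shown sit.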